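Ester to amide at the carbonyl carbon

A few compounds are considered here, and "the series" means these few. Any claim that something is new, unique, unknown or untested is made for them only; others in the source may bear on it.

Compound 2 `CCOC(=O)C1=Cc2ccc(OC)cc2OC1c1cc(OC)c(OC)c(OC)c1` stands highest of the two numbers recorded in a functional assay for inhibition of nuclear factor NF-kappa-B complex (Homo sapiens); on this read-out lower numbers stand for stronger inhibition and higher numbers for weaker inhibition: compound 2 gives 25000 nM, while compound 1 `COc1ccc2c(c1)OC(c1cc(OC)c(OC)c(OC)c1)C(C=O)=C2` gives 13500 nM, the nearest value and within the scatter. Going by the values given here, the single measured step, a 1.9-fold higher number from compound 1 to compound 2 (0.27 log units; within the scatter), alters the same carbonyl carbon that the present change alters, and it stayed within the scatter. Compound 3 `CCNC(=O)C1=Cc2ccc(OC)cc2OC1c1cc(OC)c(OC)c(OC)c1` differs from compound 2 by ethylamino in place of ethoxy on a carbonyl carbon, which, cut one bond further out, reads ethoxycarbonyl to ethylcarbamoyl. Among the compounds with values here, only that one measured step bears on this change, and it was small, so in this assay no step beyond the scatter is expected in either direction. The expected step is therefore no change at the digits printed from compound 2 to compound 3 (within the scatter). Compound 3 is estimated at 25000 nM in this assay, with a range from 10000 nM to 60000 nM.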

Compound 3, half-maximal inhibitory concentration: > 50000 nM
Compound 3 was reported as a limit (the forecaster's own chance of this, stated with the estimate: 10%); middle value at least 2.0-fold (0.30 log units) from the limit.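

In this assay compound 3 gives a limit of the assay rather than a number: the limit of > 50000 nM in this assay, at which 1 of the 3 values shown sits. Ethylamino in place of ethoxy on the carbonyl carbon gives an at least 2.0-fold higher number from compound 2 to compound 3 (0.30 log units; that floor lies within the scatter), so this change is not shown to exceed the scatter, though its full size remains unread. Ethylamino in place of hydrogen on the same carbon gives an at least 3.7-fold higher number from compound 1 to compound 3 (0.56 log units; beyond the scatter), the first step at this carbonyl carbon that lies beyond the scatter, and it points towards weaker inhibition.

How far compound 3 lies past its limit remains undefined. Whether the amide hydrogen or the ethyl chain accounts for the weaker reading also remains open, and a primary amide, a dimethylamide or a carboxylic acid on this carbonyl carbon would bear on that question.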